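Hydroxy Replaces Methyl: From Compound 3 to Compound 4

A few compounds are considered here, and "the series" means these few. Any claim that something is new, unique, unknown or untested is made for them only; others in the source may bear on it.

Compound 3 `COc1cc(N2C(N)=C(C#N)C(c3ccc(C)cc3)C3=C2CC(C)(C)CC3=O)cc(OC)c1OC` gives 90% in a functional assay on Ehrlich cells (Mus musculus) for cytotoxicity, tested at 100 ug/mL; a higher number here means a stronger effect of the compound at the concentration tested, a lower number a weaker effect. Compound 2 `COc1cc(N2C(N)=C(C#N)C(c3c(O)ccc4ccccc34)C3=C2CC(C)(C)CC3=O)cc(OC)c1OC` gives 90%, and compound 1 `COc1cc(N2C(N)=C(C#N)C(c3ccc([N+](=O)[O-])cc3)C3=C2CC(C)(C)CC3=O)cc(OC)c1OC` gives 80%; compounds 2 and 3 thus share the highest of the three numbers, while compound 1 sits within the scatter of both. Compound 4 `COc1cc(N2C(N)=C(C#N)C(c3ccc(O)cc3)C3=C2CC(C)(C)CC3=O)cc(OC)c1OC` has not been measured; it differs from compound 3 by hydroxy in place of methyl on an aromatic carbon. Going by the values given here, two measured steps bear on this change: a number 10 percentage points higher from compound 1 to compound 3 (within the scatter), and no change at the digits printed from compound 2 to compound 3 (within the scatter). Neither exchange on the saturated ring carbon moved the read-out beyond the scatter, so the replacement in compound 4 is expected to give a number 5 percentage points lower from compound 3 to compound 4 (within the scatter), nothing beyond the scatter. Compound 4 is therefore estimated at 85%, within a range from 70% to 97%.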

Compound 4, a percentage reported as activity, at one concentration (the size of the read-out at that concentration, not a potency): 100%
Compound 4: middle estimate off by 15 percentage points, on the low side, and the stated range ends below it.
By their numbers in this assay, from the lowest: compounds 1, 2, 3 and 4 (each within the scatter of the next, the first and the last beyond it).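

In this assay hydroxy in place of methyl gives a number 10 percentage points higher from compound 3 to compound 4 (within the scatter) and 4-hydroxyphenyl in place of 2-hydroxynaphthalen-1-yl gives a number 10 percentage points higher from compound 2 to compound 4 (within the scatter), so neither step separates compound 4 from these neighbours. New at this aromatic carbon is hydroxy in place of nitro, with a number 20 percentage points higher from compound 1 to compound 4 (beyond the scatter), the only step among these compounds beyond the scatter, though a modest one. No measurement shown accounts for this step. Going by these compounds, whether an amine or a carboxylic acid at this carbon would read like hydroxy or like nitro remains open. On these data alone, the potency of compound 4 also remains open, as the read-out comes from a single concentration.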